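The source may report more compounds than this note shows. Statements on the series, on what has been measured and on what is new or still open speak of the compounds shown alone.

Compound 1 `Fc1cccc(F)c1C#Cc1ccc2c(Cl)ccnc2c1` and compound 2 `Nc1ccnc2cc(C#Cc3c(F)cccc3F)ccc12` share one core, while compound 3 `Fc1cccc(F)c1C#Cc1cnc(Cl)c2ccccc12` is built from the same atoms joined differently; the difference between the two cores is not broken down here. In a functional assay on LS174T cells (Homo sapiens) for inhibition, with a stated time of 4 days, tested at 1 uM (on this read-out lower numbers stand for a weaker effect and higher numbers for a stronger effect at the one concentration tested), compound 1 gives 23.1%, compound 2 gives 23.6%, and compound 3 gives 48.1%. The change from compound 1 to compound 2 is amino in place of chloro on an aromatic carbon, and it made a number 0.5 percentage points higher from compound 1 to compound 2 (within the scatter). Compound 4 `Nc1ncc(C#Cc2c(F)cccc2F)c2ccccc12` differs from compound 3 by amino in place of chloro on an aromatic carbon, the same kind of change, though here the place is next to the ring nitrogen and para to a large group rather than opposite the ring nitrogen. The step from compound 3 to compound 4 is expected to be a number 1.1 percentage points lower from compound 3 to compound 4 (within the scatter), since the same kind of change gave a number 0.5 percentage points higher from compound 1 to compound 2 (within the scatter). Compound 4 is therefore estimated at 47%, likely between 27% and 67%.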

Compound 4, a percentage reported as inhibition, at one concentration (the size of the read-out at that concentration, not a potency): 86.2%
Compound 4: the middle estimate sits 39.2 percentage points below what was measured; the measured number lies above the stated range.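

Amino in place of chloro made a number 38.1 percentage points higher from compound 3 to compound 4 (beyond the scatter) in this assay, so on the core of compound 3 this swap has a large effect at the one concentration tested. The same swap does not behave alike on the two cores: the same change on two cores in this assay, a number 0.5 percentage points higher (within the scatter) from compound 1 to compound 2 and a number 38.1 percentage points higher (beyond the scatter) from compound 3 to compound 4, 37.6 percentage points apart, beyond the scatter of two such steps

The effect of this change therefore cannot simply be carried from one core to the other in this series, although two pairs cannot show which difference between the cores matters or how a third core would respond.

As far as these compounds go, it remains open whether the rise in compound 4 is specific to amino or would also appear with a methylamino or methoxy group at that place. From the compounds shown here alone, it is equally open whether either group would separate the two cores in the same way.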